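A benzyl swap on a weakly cytotoxic amide

The source may report more compounds than this note shows. Statements on the series, on what has been measured and on what is new or still open speak of the compounds shown alone.

- compound 1 `COc1cc([C@@H]2C[C@]2(CO)C(=O)NCc2ccc(C)cc2)cc(OC)c1OC` gives 17400 nM in the measurements
- compound 2 `COc1cc([C@H]2C[C@]2(CO)C(=O)Nc2ccccc2Cl)cc(OC)c1OC` gives 45500 nM in the measurements
- compound 3 `CCOC(=O)[C@]1(C(=O)Nc2ccccc2Cl)C[C@@H]1c1cc(OC)c(OC)c(OC)c1` gives > 100000 nM as a limit of the assay, not a number

These values come from a functional assay on HeLa cells (Homo sapiens) for cytotoxicity, read by MTT assay, with a stated time of 48 h (on this read-out lower numbers stand for stronger inhibition and higher numbers for weaker inhibition), and compound 2 holds the higher of the two true numbers, with compound 1 lying beyond the scatter on the lower side. Compound 4 `COc1cc([C@H]2C[C@]2(CO)C(=O)NCc2ccc(C)cc2)cc(OC)c1OC` has not been measured yet. Going from compound 2 to compound 4 places 4-methylbenzyl in place of 2-chlorophenyl on an amide-type nitrogen, counted as 4-methylbenzyl in place of 2-chlorophenyl on an amide-type nitrogen for this change. Going by the values given here, the only measured step is an at least 2.1-fold higher number from compound 2 to compound 3 (0.34 log units; beyond the scatter) when ethoxycarbonyl replaces hydroxymethyl on a saturated ring carbon, but that change lies elsewhere, so it offers little guidance here. The better clue is that compound 1 also carries 4-methylbenzyl and gives 17400 nM in the same test. A modest move to a lower number, meaning somewhat stronger inhibition, is therefore expected in this assay for this swap. The expected step is a 2.1-fold lower number from compound 2 to compound 4 (0.32 log units; beyond the scatter) and remains uncertain. The estimated value for compound 4 is 22000 nM with an expected range from 7000 nM to 70000 nM on present evidence.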

Compound 4, half-maximal inhibitory concentration: 57800 nM
Beside the measured number, compound 4's estimate is 2.6-fold (0.42 log units) below it; the measured number falls inside the stated range.
By their numbers in this assay, from the lowest: compound 1; then compounds 2 and 4 (each within the scatter of the next). At a limit, above all of these: compound 3.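

In this assay the swap on the amide-type nitrogen gives a 1.3-fold higher number from compound 2 to compound 4 (0.10 log units; within the scatter) and so cannot be told apart from no change, which means 4-methylbenzyl alone does not bring the lower number hoped for here. Going by these compounds alone, the configuration of the shared core makes the larger difference, with a 3.3-fold higher number from compound 1 to compound 4 (0.52 log units; beyond the scatter) as the only change in drawing. This gap can be assigned to stereochemistry, not to a change of group, because of one plain structural point: the fact that compounds 1 and 4 differ only in the configuration as drawn.

Still open, on these data alone, is whether 2-chlorophenyl would give a lower number in the configuration of compound 1, so the two changes cannot yet be judged together. Also open, as far as these compounds go, is how a longer chain on the amide-type nitrogen, or a carboxylic acid in place of hydroxymethyl, would read in this test.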